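A few compounds are considered here, and "the series" means these few. Any claim that something is new, unique, unknown or untested is made for them only; others in the source may bear on it.

Cytotoxicity in a toxicity assay on NIH3T3 cells (Mus musculus) for cytotoxicity, read by resazurin assay (a lower number here means that less compound is needed, a higher number that more compound is needed for the effect), is the only read-out for this set. Compound 2 `O=C(OC1CCCCC1)c1ccc(NCc2cncn2Cc2ccc(-c3ccccc3)cc2)cc1-c1ccccc1` sits at the assay limit in this assay, giving > 10000 nM, which is a limit rather than a number. Compound 1 `COC(=O)c1ccc(NCc2cncn2Cc2cccc(Cl)c2)cc1-c1ccccc1` likewise returns a limit in this assay, > 10000 nM. Compound 3 `COC(=O)c1ccc(NCc2cncn2Cc2cccc(OC)c2)cc1-c1ccccc1` has no result in this assay, "not determined" (no result reported). Every measured member thus stands at the same limit (the limit of > 10000 nM in this assay, at which 2 of the 3 values shown sit), and compound 2 stands with them. Compound 4 `COc1ccc(NCc2cncn2Cc2ccc(-c3ccccc3)cc2)cc1-c1ccccc1` differs from compound 2 by methoxy in place of cyclohexyloxycarbonyl on an aromatic carbon. For the measured compounds named here, no measured pair differing in one place is available, so no step size is known; for compound 4 the expectation is a change of no more than the usual scatter in this assay, a step that the limit leaves unreadable from compound 2 to compound 4. Compound 4 is estimated at 15000 nM, between 5000 nM and 50000 nM, and is expected to be reported again as a limit.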

Compound 4, half-maximal effective concentration: > 1000 nM
Compound 4 gave a limit, no number; the forecaster's own chance of this, stated with the estimate: 75%; the middle value does not contradict the limit.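

For the compounds shown here, compound 2 and compound 4 both return limits rather than numbers in this assay, so no step between them can be read. The compounds shown leave open whether methoxy in place of cyclohexyloxycarbonyl changes cytotoxicity at all.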